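Swapping Trifluoromethyl for Chloro on a Shared Diaryl Urea

The source may report more compounds than this note shows. Statements on the series, on what has been measured and on what is new or still open speak of the compounds shown alone.

Compound 2 `COc1cc2cc(Oc3ccc(NC(=O)Nc4ccc(Cl)c(C(F)(F)F)c4)cc3)c(C)nc2cc1OC` was tested in a functional assay on IGROV-1 cells (Homo sapiens) for inhibition, read by sulforhodamine B assay, with a stated time of 48 h (on this read-out higher numbers stand for weaker inhibition of growth and lower numbers for stronger inhibition of growth), where compound 2 gives 2340 nM. Among the measured compounds shown here, only one other compound has been measured: compound 1 `COc1cc2cc(Oc3ccc(NC(=O)Nc4cccc(C(F)(F)F)c4)cc3)c(C)nc2cc1OC`, which in this assay gives 2950 nM. For the measured compounds named here, the single measured step, a 1.3-fold lower number from compound 1 to compound 2 (0.10 log units; within the scatter), adds a chloro group and lies within the scatter, so compound 2 and compound 1 cannot be told apart on these numbers. Compound 3 `COc1cc2cc(Oc3ccc(NC(=O)Nc4ccc(Cl)c(Cl)c4)cc3)c(C)nc2cc1OC` has not yet been measured. It differs from compound 2 by chloro in place of trifluoromethyl on an aromatic carbon. Going by the values given here, no measured step shows this exchange of one group for another; the only step known is the small one from adding chloro, which gives no direct guide. The expectation for compound 3 is therefore a number near that of compound 2 with wide uncertainty, an expected step of a 1.3-fold higher number from compound 2 to compound 3 (0.11 log units; within the scatter). Compound 3 is estimated at 3000 nM, between 1000 nM and 9000 nM.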

Compound 3, concentration for 50% growth inhibition: 5610 nM
Compound 3: the middle estimate sits 1.9-fold (0.27 log units) below what was measured; the measured number falls inside the stated range.
By their numbers in this assay, from the lowest: compounds 2, 1 and 3 (each within the scatter of the next, the first and the last beyond it).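

In this assay, among the compounds shown here, exchanging the trifluoromethyl group of compound 2 for chloro gives a 2.4-fold higher number from compound 2 to compound 3 (0.38 log units; beyond the scatter) and is the first step here to lie beyond the scatter, so the group at this position on the aromatic ring does affect the read-out, though only modestly. The change from the 3-(trifluoromethyl)phenyl group to the 3,4-dichlorophenyl group gives a 1.9-fold higher number from compound 1 to compound 3 (0.28 log units; within the scatter) and stays within the scatter, so that pair cannot be told apart on these numbers. Nothing available here explains the weaker growth inhibition seen with chloro at this position.

As far as these compounds go, how a methyl, a methoxy, an amine or a carboxylic acid at this position would compare remains open. It is also unknown whether the exchange of trifluoromethyl for chloro would give a similar step on a ring without the second chloro group.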